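The source may hold more compounds than are shown below. What is called first, only, known or untested is meant among the compounds shown, and "the series" means these compounds.

Of the compounds shown here, three of one series have been tested in a functional assay on MGC-803 cells (Homo sapiens) for inhibition, read by MTT assay, with a stated time of 72 h; on this read-out lower numbers stand for stronger inhibition and higher numbers for weaker inhibition. Compound 1 `O=C(/C=C/c1ccc(Cl)c(Cl)c1)/C=C/c1ccccc1Oc1ncnc2ccc(Cl)cc12` gives 16200 nM. Compound 2 `O=C(/C=C/c1ccc(Oc2ncnc3ccc(Cl)cc23)cc1)/C=C/c1ccc(Cl)c(Cl)c1` gives 16900 nM, a number within the scatter of that of compound 1; the difference between the two cores is not broken down here. Compound 3 `O=C(/C=C/c1ccc(Oc2ncnc3ccc(Cl)cc23)cc1)/C=C/c1cccc(Cl)c1Cl` gives 7300 nM. Compound 3 differs from compound 2 by a single change (2,3-dichlorophenyl in place of 3,4-dichlorophenyl on a double-bonded chain carbon bound to a double-bonded chain carbon), and this change made a 2.3-fold lower number from compound 2 to compound 3 (0.36 log units; beyond the scatter). Compound 4 `O=C(/C=C/c1ccccc1Oc1ncnc2ccc(Cl)cc12)/C=C/c1cccc(Cl)c1Cl` has not been measured; it differs from compound 1 by the same change (2,3-dichlorophenyl in place of 3,4-dichlorophenyl on a double-bonded chain carbon bound to a double-bonded chain carbon), now carried out on the core of compound 1 rather than on that of compound 2. Because a 2.3-fold lower number from compound 2 to compound 3 (0.36 log units; beyond the scatter) was modest yet beyond the scatter, compound 4 is expected to show a step of similar size from compound 1 in this assay, namely a 2.2-fold lower number from compound 1 to compound 4 (0.33 log units; beyond the scatter). That expectation rests on one measured pair only and is therefore held loosely. For compound 4 the estimated value is 7500 nM, with an expected range from 3500 nM to 16000 nM.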

Compound 4, half-maximal inhibitory concentration: 5210 nM
The estimate for compound 4 lay 1.4-fold (0.16 log units) above the measured number, and the stated range covers the measured number.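

In this assay, putting 2,3-dichlorophenyl in place of 3,4-dichlorophenyl on the second core gave a 3.1-fold lower number from compound 1 to compound 4 (0.49 log units; beyond the scatter), so the change moved the number in the same direction, towards stronger inhibition, as it had on the first core. Set side by side, the two steps cannot be told apart in size: the same change on two cores in this assay, a 2.3-fold lower number (0.36 log units; beyond the scatter) from compound 2 to compound 3 and a 3.1-fold lower number (0.49 log units; beyond the scatter) from compound 1 to compound 4, 1.3-fold (0.13 log units) apart, within the scatter of two such steps. This shows that, across these two cores and in this one assay, the change carried over with its direction and approximate size intact, but two pairs do not show that it would do so on a further core, and they do not explain why it works.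

The compounds shown leave open how the number would move if methoxy groups, fluorine atoms or an amine took the place of the two chlorines on this phenyl ring. They also leave open whether the same step would appear in a different cell line.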